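Taking the ethoxy group off compound 2

The source may report more compounds than this note shows. Statements on the series, on what has been measured and on what is new or still open speak of the compounds shown alone.

Compound 1 `CCOc1cccc(-c2ncnn2-c2cc(OC)c(OC)c(OC)c2)c1`: > 10000 nM (a limit, not a number)
Compound 2 `CCOc1ccc(-c2ncnn2-c2cc(OC)c(OC)c(OC)c2)cc1`: 100 nM

Within the data shown here, in a functional assay on A549 cells (Homo sapiens) for antiproliferative activity, read by MTT assay, with a stated time of 72 h (on this read-out lower numbers stand for stronger inhibition and higher numbers for weaker inhibition), compound 2 gives 100 nM, the only true number available so far. Compound 1 gives > 10000 nM, which is a limit of the assay. Compound 3 `COc1cc(-n2ncnc2-c2ccccc2)cc(OC)c1OC` differs from compound 2 by a single change hydrogen in place of ethoxy on an aromatic carbon, para to a large group. Among the measured compounds shown here, no measured pair shows this change directly, so any forecast is loose. Compound 2 reaches 100 nM with the ethoxy in place, so losing that group is expected to weaken inhibition in this assay by clearly more than the scatter. The expected step is a 30-fold higher number from compound 2 to compound 3 (1.48 log units; beyond the scatter). The estimated value for compound 3 is 3000 nM, with an expected range from 400 nM to 10000 nM, and a reading at the limit of the assay would not surprise.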

Compound 3, half-maximal inhibitory concentration: > 10000 nM
Compound 3: only a limit was reported; the forecaster's own chance of this, stated with the estimate: 35%; at least 3.3-fold (0.52 log units) between middle value and limit.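

In this assay, replacing the ethoxy group with hydrogen, para to a large group, gives an at least 100-fold higher number from compound 2 to compound 3 (2.00 log units; beyond the scatter). Among these compounds, this is the first direct reading of the change, and it shows that the activity of compound 2 is not kept once the ethoxy group is gone; the true step may be larger still, as the value of compound 3 is a limit and not a number. The step from compound 1 to compound 3 cannot be read, and neither compound can be placed more exactly: the limit of > 10000 nM in this assay, at which 2 of the 3 values shown sit.

As far as these compounds go, what remains open is whether the ethoxy group is the best choice at this position, or whether a longer chain such as propoxy, a smaller hydroxyl or an amine would serve as well. Any such group could give a true number, which would show how much of the activity depends on what sits there.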